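The source may hold more compounds than are shown below. What is called first, only, known or untested is meant among the compounds shown, and "the series" means these compounds.

Compound 1 `O=C(COc1ccc(C(=O)/C=C/c2ccc(Cl)cc2Cl)cc1)N[C@H]1CCOC1=O` is one of two chalcone-type amides in this set. In a functional assay on PC-3 cells (Homo sapiens) for antiproliferative activity, read by MTT assay, with a stated time of 72 h (on this read-out higher numbers stand for weaker inhibition and lower numbers for stronger inhibition), compound 1 gives 8040 nM. Compound 2 `O=C(COc1ccc(C(=O)/C=C/c2ccccc2Cl)cc1)N[C@H]1CCOC1=O` differs from it by hydrogen in place of chloro on an aromatic carbon, and in this assay compound 2 gives 4610 nM. The step of a 1.7-fold lower number from compound 1 to compound 2 (0.24 log units; within the scatter) is therefore a small one.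

Compound 3 `O=C(CNc1cccc(Cl)c1)N[C@H]1CCOC1=O` is built on a different core. The difference between the core of compound 3 and the core of compound 1 is not broken down here. In this assay compound 3 reaches only the limit of the method and gives > 64000 nM, which is a boundary rather than a number (the limit of > 64000 nM in this assay, at which 1 of the 3 values shown sits).

Compound 4 `O=C(CNc1ccccc1)N[C@H]1CCOC1=O` has not yet been measured. It differs from compound 3 by hydrogen in place of chloro on an aromatic carbon. Among the measured compounds shown here, this is the same kind of change as the one from compound 1 to compound 2, though the surroundings differ: in compound 1 the leaving chloro sits meta to a chloro group and para to a large group, while in compound 3 it sits meta to a large group.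

The earlier step of a 1.7-fold lower number from compound 1 to compound 2 (0.24 log units; within the scatter) gave little movement, and compound 3 is itself only at the limit, so compound 4 is expected to move by about a step that the limit leaves unreadable from compound 3 to compound 4. Compound 4 is expected to come out near 70000 nM in this assay, most likely again as a limit rather than a number.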

Compound 4, half-maximal inhibitory concentration: > 64000 nM
Compound 4: only a limit was reported; the forecaster's own chance of this, stated with the estimate: 75%; the middle value is on the limit's open side.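

In this assay compound 4 gives > 64000 nM, which is a limit and not a number. Compound 3 stands at the same kind of limit, so no step can be read between compound 3 and compound 4: the limit of > 64000 nM in this assay, at which 2 of the 4 values shown sit.

The compounds shown leave open whether hydrogen in place of chloro changes the read-out at all on the core of compound 3.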